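This account rests on a few compounds, and the source may have more. Where it says the series, first, only, none or still open, it means among the compounds named here.

Measured compounds:
compound 1 `COc1ccc(O)c2c1C(=O)C=C(CCC=C(C)C)C2=O` — 7640 nM
compound 2 `COc1ccc(O)c2c1C(=O)C(CCC=C(C)C)=CC2=O` — 8050 nM

In a functional assay on HepG2 cells (Homo sapiens) for cytotoxicity, read by MTT assay, with a stated time of 48 h (a higher number here means a weaker inhibitor, a lower number a stronger inhibitor), compound 1 gives 7640 nM. In this assay compound 2 gives 8050 nM. The two numbers lie within the scatter of each other, so neither compound is set apart from the other on the evidence at hand; compound 1 stands together with compound 2 at a single level, and nothing more can be read from the pair.

Compound 3 `COc1ccc(O)c2c1C(=O)C=C([C@H](CC=C(C)C)OC(C)=O)C2=O` has not yet been measured in this assay. It differs from compound 1 by acetoxy in place of hydrogen on a saturated chain carbon bound to a double-bonded ring carbon and a saturated chain carbon. Among the compounds with values here, no pair among the measured compounds isolates a change of this kind, so there is no step in this assay to lean on. Within the data shown here, the only guidance is that the two measured compounds sit at the same level, which gives no reason to expect the acetoxy group to move the number far. The expected outcome is therefore a step within the scatter, with no clear direction, as a 1.0-fold lower number from compound 1 to compound 3 (0.01 log units; within the scatter). Compound 3 is expected to give about 7500 nM in this assay, with a range from 3000 nM to 18000 nM.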

Compound 3, half-maximal inhibitory concentration: 870 nM
Compound 3: middle estimate off by 8.6-fold (0.94 log units), on the high side; measured number outside the range, below it.
By their numbers in this assay, from the lowest: compound 3; then compounds 1 and 2 (each within the scatter of the next).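

In this assay the saturated chain carbon bound to a double-bonded ring carbon and a saturated chain carbon emerges as a position where a substituent can change the read-out: acetoxy in place of hydrogen gives an 8.8-fold lower number from compound 1 to compound 3 (0.94 log units; beyond the scatter) and this step lies beyond the scatter. Within the data shown here, the earlier pair, compound 1 and compound 2, stood at one level and offered no step at this carbon, so this is the first sign that the number responds to a change on the chain. No measurement at hand bears on what lies behind the step.

As far as these compounds go, it remains open whether the whole acetoxy group is needed at this carbon or whether a hydroxyl group, a longer ester such as butanoyloxy, or an amine would give a similar number. Also open, from the compounds shown here alone, are the effect of the opposite configuration at this carbon and whether acetoxy at the matching chain carbon of compound 2 would produce a step of similar size.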